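A few compounds are considered here, and "the series" means these few. Any claim that something is new, unique, unknown or untested is made for them only; others in the source may bear on it.

Measured so far:
- compound 1, `COc1cc(C)cc(-c2nn(CC#N)cc2-c2ccc(-c3cccc(C(C)=O)c3)nc2)c1`: 27% in a functional assay on K562 cells (Homo sapiens) for cytotoxicity, read by sulforhodamine B assay, with a stated time of 48 h, tested at 100 nM; a higher number here means a weaker effect of the compound at the concentration tested, a lower number a stronger effect
- compound 2, `Cc1cc(O)cc(-c2nn(CC#N)cc2-c2ccnc(-c3ccc(Oc4ccccc4)cc3)c2)c1`: 46% in this assay
- compound 3, `COc1cc(C)cc(-c2nn(CC#N)cc2-c2ccnc(-c3ccc(N(C)C)cc3)c2)c1`: 10% in this assay

Compound 3 gives the lowest of the three numbers, so at this concentration it shows the strongest effect on the cells. Compound 1 stands closer to it, and compound 2 stands furthest away, and both differences lie beyond the usual scatter of repeated measurements.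

Compound 4, `Cc1cc(O)cc(-c2nn(CC#N)cc2-c2ccnc(-c3ccc(N(C)C)cc3)c2)c1`, is the compound still to be measured. It differs from compound 3 in one place: hydrogen in place of methyl on an oxygen on an aromatic ring. Going by the values given here, no pair of measured compounds shows this change on its own, so there is no measured step to lean on. Compound 2 carries the hydroxy group and gives a weaker result than compound 3, but compound 2 also differs elsewhere, so that gap cannot be read as the effect of the hydroxy group alone.

The expected step from compound 3 to compound 4 in this assay is therefore small, a number 8 percentage points higher from compound 3 to compound 4 (within the scatter), pointing toward a slightly weaker effect but not clearly beyond the scatter. Compound 4 is expected to give about 18% in this assay, within a range from 5% to 40%.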

Compound 4, a percentage reported as activity, at one concentration (the size of the read-out at that concentration, not a potency): 80%
Estimate against measurement, compound 4: 62 percentage points below; the whole stated range lies below it.
By their numbers in this assay, from the lowest: compound 3; then compound 1; then compound 2; then compound 4.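

Keeping the dimethylamino group fixed, the change from methoxy to hydroxy is far from minor in this assay: it gives a number 70 percentage points higher from compound 3 to compound 4 (beyond the scatter), so the effect on the cells at the tested concentration is largely lost. Keeping the hydroxy group fixed, dimethylamino in place of phenoxy gives a number 34 percentage points higher from compound 2 to compound 4 (beyond the scatter), so the result with a hydroxy group also depends strongly on the second group. Nothing available explains why either change has so large an effect.

As far as these compounds go, it remains open whether methoxy to hydroxy would give a step of similar size with phenoxy in place of dimethylamino. From the compounds shown here alone, it is also open whether an ethoxy group or an amine in place of the methoxy group would give a number closer to that of the methoxy or the hydroxy compound.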